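Carboxy for hydroxymethyl on a longer-chain analogue

The compounds below may be only part of what the source reports. "The series", "measured", "known", "first", "only" and "open" are said of these compounds alone.

Compound 1 `Cn1nc(Cc2nnc(SCC(=O)Nc3ccc(Cl)cc3Cl)n2CCCO)c2ccccc2c1=O` is the starting point. In an assay on NK92 cells for inhibition of interleukin-15 (Homo sapiens), read by AlphaScreen, with stated times of 30 min and 1 h (on this read-out lower numbers stand for stronger inhibition and higher numbers for weaker inhibition), compound 1 gives > 30000 nM, which is a limit of the assay rather than a number. Compound 2 `Cn1nc(Cc2nnc(SCC(=O)Nc3ccc(Cl)cc3Cl)n2CCC(=O)O)c2ccccc2c1=O` differs from it by one change, (carboxy in place of hydroxymethyl on a saturated chain carbon, two bonds along the chain from an aromatic nitrogen). In this assay compound 2 gives > 30000 nM, again a limit. The step that the two limits leave unreadable from compound 1 to compound 2 therefore cannot be read.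

Compound 3 `Cn1nc(Cc2nnc(SCCCCCCCC(=O)Nc3ccc(Cl)cc3Cl)n2CCCO)c2ccccc2c1=O` carries a longer chain; the difference between its core and that of compound 1 is not broken down here. In this assay compound 3 gives > 30000 nM, also a limit.

Compound 4 `Cn1nc(Cc2nnc(SCCCCCCCC(=O)Nc3ccc(Cl)cc3Cl)n2CCC(=O)O)c2ccccc2c1=O` has not been measured. It differs from compound 3 by carboxy in place of hydroxymethyl on a saturated chain carbon, two bonds along the chain from an aromatic nitrogen, the same change as from compound 1 to compound 2, made twice in all among these compounds. Because (the limit of > 30000 nM in this assay, at which 3 of the 3 values shown sit), no readable shift has been seen for this change, and compound 4 is expected to behave like compound 3: the expected step that the limit leaves unreadable from compound 3 to compound 4 is small. The estimate for compound 4 in this assay is 60000 nM, most likely reported only as a limit.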

Compound 4, half-maximal inhibitory concentration: 9500 nM
For compound 4 the middle estimate is 6.3-fold (0.80 log units) above the measured one, outside the stated range (below it).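

On the longer-chain core, carboxy in place of hydroxymethyl is readable in this assay and gives an at least 3.1-fold lower number from compound 3 to compound 4 (0.49 log units; beyond the scatter); the starting value of that step, from compound 3, is a limit and not a number. On the core of compound 1 the same change cannot be read, because both ends of that step are limits: the limit of > 30000 nM in this assay, at which 3 of the 4 values shown sit. The change therefore has a shown effect on one core only, and the compounds neither prove nor rule out that it carries over to the shorter-chain core, where any shift would have to stay hidden beyond the limit.

Still open, going by these compounds, is whether a chain of intermediate length on the sulfur side would be enough for the change to become readable in this assay. Also open, on these data alone, is whether the carboxy group itself is required, which a methyl ester or a primary amide at the same place on the longer-chain core would help to show.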